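Replacing 1-methyl-1H-pyrrol-2-yl with 8-hydroxyquinolin-5-yl

This account rests on a few compounds, and the source may have more. Where it says the series, first, only, none or still open, it means among the compounds named here.

Measured in a functional assay on U-87MG ATCC cells (Homo sapiens) for antiproliferative activity, with a stated time of 3 days; on this read-out higher numbers stand for an effect only at larger amounts of compound and lower numbers for an effect already at smaller amounts:
- Compound 1 `Oc1ccc(CN(Cc2ccccc2)Cc2ccc(O)c3ncccc23)c2cccnc12`: < 0.5 uM, a limit of the assay
- Compound 2 `Oc1ccc(CN(Cc2cccc(C(F)(F)F)c2)Cc2ccc(O)c3ncccc23)c2cccnc12`: 2 uM
- Compound 3 `Cn1cccc1CN(Cc1ccc(O)c2ncccc12)Cc1ccc(O)c2ncccc12`: 2 uM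

The last two entries agree: no change at the digits printed from compound 2 to compound 3 (within the scatter). Compound 1 stands apart, with an at least 4.0-fold higher number from compound 1 to compound 3 (0.60 log units; beyond the scatter). The next change gives compound 4 `Oc1ccc(CN(Cc2ccc(O)c3ncccc23)Cc2ccc(O)c3ncccc23)c2cccnc12`, with 8-hydroxyquinolin-5-yl in place of 1-methyl-1H-pyrrol-2-yl on a saturated chain carbon bound to an amine nitrogen. That same place was altered in the step of an at least 4.0-fold higher number from compound 1 to compound 3 (0.60 log units; beyond the scatter), so the group there can shift the number. Like the phenyl of compound 1, the entering group holds a six-membered aromatic ring of carbon only. The expected step is a 2.5-fold lower number from compound 3 to compound 4 (0.40 log units; beyond the scatter), a modest one toward a lower number. The estimate for compound 4 is 0.8 uM, within 0.25 uM to 2.5 uM.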

Compound 4, concentration for half-maximal effect: > 10 uM
Compound 4 gave a limit, no number; the forecaster's own chance of this, stated with the estimate: 35%; middle value at least 12-fold (1.09 log units) away from the limit.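

In this assay, compound 4 gives a limit and not a number: the limit of > 10 uM in this assay, at which 1 of the 4 values shown sits. On a saturated chain carbon bound to an amine nitrogen, 8-hydroxyquinolin-5-yl brings an at least 5.0-fold higher number from compound 3 to compound 4 (0.69 log units; beyond the scatter), an at least 5.0-fold higher number from compound 2 to compound 4 (0.69 log units; beyond the scatter) and an at least 20-fold higher number from compound 1 to compound 4 (1.30 log units; beyond the scatter). A six-membered aromatic ring of carbon only, shared with the phenyl of compound 1, therefore does not alone keep the number low at this place.

Going by these compounds, because compound 4 gives only a limit, the true size of these steps stays open. So does which part of the entering group matters, a question that hydroxyphenyl or naphthyl at this place could address.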